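Swapping a Hydrazide Chain for a Methyl Ester Ether

The source may report more compounds than this note shows. Statements on the series, on what has been measured and on what is new or still open speak of the compounds shown alone.

Compound 1 `NNC(=O)CCc1ccncc1-c1ccc2ccccc2c1`: 102%
Compound 2 `COc1ccc(-c2cnccc2/C=C/C(=O)N2CC(OC)C2)cc1OC`: 87%

Both compounds were tested in an assay on a protein complex for inhibition of CDK8/Cyclin C (Homo sapiens), with a stated time of 1 h, tested at 10 uM; a higher number here means more inhibition at the concentration tested (going by the name of the read-out), a lower number less inhibition. Compound 1 stands highest of the two numbers; the nearest, compound 2, lies lower by a gap beyond the usual scatter. The unmeasured compound 3 `COC(=O)COc1ccncc1-c1ccc2ccccc2c1` keeps the core of compound 1 and changes a single group: (methoxycarbonyl)methoxy in place of 2-(aminocarbamoyl)ethyl on an aromatic carbon. The change sits on an aromatic carbon of a six-membered aromatic ring with 1 nitrogen, opposite the ring nitrogen. Among the compounds with values here, no step between two measured compounds is available to calibrate this change, so the expectation rests on compound 1 alone. Since compound 1 gives 102%, the number can hardly rise, and with nothing to show the change is neutral a modest fall is assumed. The step of a number 27 percentage points lower from compound 1 to compound 3 (beyond the scatter) is expected to be downward, near or somewhat beyond the scatter. Compound 3 is estimated at 75%, within 40% to 100%.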

Compound 3, a percentage reported as inhibition, at one concentration (the size of the read-out at that concentration, not a potency): 11%
Estimate against measurement, compound 3: 64 percentage points above; the whole stated range lies above it.
By their numbers in this assay, from the lowest: compound 3; then compound 2; then compound 1.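

Putting (methoxycarbonyl)methoxy in place of 2-(aminocarbamoyl)ethyl, on the aromatic carbon opposite the ring nitrogen, gives a number 91 percentage points lower from compound 1 to compound 3 (beyond the scatter) in this assay. This position is therefore far from indifferent to what it carries, even though the two chains match in heavy-atom count and neither contains a ring. The change alters several things at once, including the loss of both hydrogen-bond donors, and nothing available here explains the fall or separates these differences.

On these data alone, it remains open whether the whole hydrazide chain is needed, or whether a simple primary amide or a carboxylic acid on the same chain would keep the inhibition. A plain amine at the end of a longer chain would also test whether a nitrogen alone is enough.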